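The compounds below may be only part of what the source reports. "The series", "measured", "known", "first", "only" and "open" are said of these compounds alone.

Measured so far:
- compound 1, `CCOc1ccc2c(NCCCN(C)C)ccnc2c1`; in a physicochemical assay for solubility (a higher number here means a more soluble compound, a lower number a less soluble compound), compound 1 stops at the limit > 10000 ug/mL.
- compound 2, `CCCCCCOc1ccc2c(NCCN(C)C)ccnc2c1`; in this assay compound 2 likewise stops at the limit > 10000 ug/mL.
- compound 3, `CN(C)CCNc1ccnc2cc(OCc3ccc(F)cc3)ccc12`; in this assay compound 3 also stops at the limit > 10000 ug/mL.

Compound 3 therefore stands at the upper limit, and so does every other measured compound (the limit of > 10000 ug/mL in this assay, at which 3 of the 3 values shown sit). Within the data shown here, the only measured step that changes the group on the saturated chain carbon bound to an oxygen on the aromatic ring is a step that the two limits leave unreadable from compound 2 to compound 3; with both ends at a limit, its size cannot be read.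

Compound 4 `CCOc1ccc2c(NCCN(C)C)ccnc2c1` differs from compound 3 by methyl in place of 4-fluorophenyl on a saturated chain carbon bound to an oxygen on an aromatic ring. Compound 1 carries the same ethyl on that carbon and sits at the limit (the limit of > 10000 ug/mL in this assay, at which 3 of the 3 values shown sit), and the change in the amine-bearing chain between compound 1 and compound 4 is not covered by any measured step. The step of a number no higher from compound 3 to compound 4 (the limit leaves the size open) is expected to be none beyond the scatter, most likely ending at the limit again. Compound 4 is estimated at 10000 ug/mL in this assay, within 5000 ug/mL to 30000 ug/mL.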

Compound 4, solubility: > 10000 ug/mL
Compound 4 gave a limit, no number; the forecaster's own chance of this, stated with the estimate: 85%; the middle value sits exactly at the limit.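

In this assay, among these compounds, compound 4 gives > 10000 ug/mL, a limit and not a number, so no step from compound 1, compound 2 or compound 3 to compound 4 can be read. The compounds shown leave open the size of every one of these changes, with no actual number among them: the limit of > 10000 ug/mL in this assay, at which 4 of the 4 values shown sit.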